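A few compounds are considered here, and "the series" means these few. Any claim that something is new, unique, unknown or untested is made for them only; others in the source may bear on it.

Among the measured compounds shown here, in an ADME assay on microsomes from liver (Homo sapiens) for pharmacokinetics, using NADPH, with a stated time of 30 min, tested at 1 uM (on this read-out lower numbers stand for slow clearance and higher numbers for fast clearance), compound 2 `CCNC(=O)c1c(-c2ccccc2)c([C@H](C)Nc2ncnc(N)c2C#N)nc2ccc(F)cc12` gives 22 mL.min-1.g-1, the only true number so far. For the measured compounds named here, its one neighbour is compound 1 `C[C@H](Nc1ncnc(N)c1C#N)c1nc2ccc(F)cc2c(C(N)=O)c1-c1ccccc1`, which differs by having hydrogen in place of ethyl on an amide-type nitrogen. Compound 1 reads < 14 mL.min-1.g-1, and this is a limit of the assay and not a number. The measured step is therefore an at least 1.5-fold higher number from compound 1 to compound 2 (0.19 log units; that floor lies within the scatter). Compound 3 `CC(C)NC(=O)c1c(-c2ccccc2)c([C@H](C)Nc2ncnc(N)c2C#N)nc2ccc(F)cc12` changes the same side chain from ethyl to isopropyl: methyl in place of hydrogen on a saturated chain carbon bound to an amide-type nitrogen and a saturated chain carbon. Going by the values given here, only one measured step bears on this change, and its size is not fully known. Among the compounds with values here, with an at least 1.5-fold higher number from compound 1 to compound 2 (0.19 log units; that floor lies within the scatter) as the sole guide, a small rise in this assay is expected, or none beyond the scatter. The estimate is a 1.2-fold higher number from compound 2 to compound 3 (0.09 log units; within the scatter). The expected value for compound 3 is 27 mL.min-1.g-1, with an estimated range from 15 mL.min-1.g-1 to 50 mL.min-1.g-1.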

Compound 3, intrinsic clearance in microsomes: 51 mL.min-1.g-1
Beside the measured number, compound 3's estimate is 1.9-fold (0.28 log units) below it; measured number outside the range, above it.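

In this assay, adding one methyl to the ethyl side chain gives a 2.3-fold higher number from compound 2 to compound 3 (0.37 log units; beyond the scatter), so a change at this position, on a saturated chain carbon bound to an amide-type nitrogen and a saturated chain carbon, now clearly exceeds the scatter, which the earlier pair could not show. Replacing the amide hydrogen with isopropyl gives an at least 3.6-fold higher number from compound 1 to compound 3 (0.56 log units; beyond the scatter), a step that also lies beyond the scatter. Compound 1 reads as a limit of the assay and not a number, so this step is only a floor and its full size cannot be read: the limit of < 14 mL.min-1.g-1 in this assay, at which 1 of the 3 values shown sits.

From the compounds shown here alone, whether a longer chain such as propyl or a bulkier group such as tert-butyl would raise the clearance number further remains open. Also open, going by these compounds, is how a hydroxyl group or an amine on this side chain would change it.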